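Working notes: cytotoxicity series, step from compound 2 to compound 4

The source may report more compounds than this note shows. Statements on the series, on what has been measured and on what is new or still open speak of the compounds shown alone.

Measured compounds in an ADME assay on MDCK cells (Canis lupus familiaris) for cytotoxicity, read by MTT assay, with a stated time of 3 days; a lower number here means that less compound is tolerated, a higher number that more compound is tolerated:
compound 1 `CC1(C)C[C@H](O)C[C@](C)(CNc2ccccc2)C1`: 37000 nM
compound 2 `CC1(C)C[C@H](O)C[C@](C)(CNc2ccc(Cl)cc2)C1`: 8100 nM
compound 3 `CC1(C)C[C@H](O)C[C@](C)(CNc2cc(F)cc(Cl)c2)C1`: 4400 nM

Compound 2 sits second highest of the three numbers in this assay. Its nearest neighbour is compound 3, whose value lies within the scatter of that of compound 2, so no order between these two can be read. Among the compounds with values here, the one step beyond the scatter runs a 4.6-fold lower number from compound 1 to compound 2 (0.66 log units; beyond the scatter), a modest drop on adding a chloro group to the ring of compound 1.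

The unmeasured compound 4 `CC1(C)C[C@H](O)C[C@](C)(CNc2ccc(Cl)c(S(N)(=O)=O)c2)C1` is reached from compound 2 by sulfamoyl in place of hydrogen on an aromatic carbon, the new group entering ortho to the chloro group and meta to a large group. Within the data shown here, no measured step places a sulfamoyl group, or any group with hydrogen-bond donors and acceptors, on this ring; the only precedent is the chloro step from compound 1 to compound 2, which was modest and downward. A change of this kind is therefore hard to anchor, and the expectation is a step no larger than modest in either direction, most likely within the scatter.

Compound 4 is expected to give about 12000 nM in this assay, within a range of 4500 nM to 32000 nM, that is a step of a 1.5-fold higher number from compound 2 to compound 4 (0.17 log units; within the scatter).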

Compound 4, half-maximal cytotoxic concentration: 71200 nM
Estimate against measurement, compound 4: 5.9-fold (0.77 log units) below; measured number above the stated range.
By their numbers in this assay, from the lowest: compounds 3 and 2 (each within the scatter of the next); then compounds 1 and 4 (each within the scatter of the next).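

In this assay, sulfamoyl in place of hydrogen on an aromatic carbon, ortho to a chloro group, gives an 8.8-fold higher number from compound 2 to compound 4 (0.94 log units; beyond the scatter) and so shows that this position responds to substitution, with more compound tolerated rather than less. The earlier step on this ring, a 4.6-fold lower number from compound 1 to compound 2 (0.66 log units; beyond the scatter) on placing a chloro group, had shown only a downward change, whereas the new step runs the other way with the chloro group still in place in compound 4. No evidence on hand accounts for the size or direction of the new step.

Open, from the compounds shown here alone, is whether the step belongs to sulfamoyl itself or would also come with other groups at the same place, such as a methyl group, a carboxylic acid, an amine or a methylsulfonyl group, which would tell the two readings apart. Also open, going by these compounds, is whether sulfamoyl at this place gives a step of similar size without the chloro group, on the ring of compound 1, or with the fluoro and chloro groups of compound 3.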